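The source may hold more compounds than are shown below. What is called first, only, known or untested is meant among the compounds shown, and "the series" means these compounds.

Working notes on the series. All three measured compounds share one core, differ only in the substituted phenyl at its far end, and are compared in a functional assay on HeLa cells (Homo sapiens) for inhibition, read by cell counting, with a stated time of 4 days; on this read-out lower numbers stand for stronger inhibition and higher numbers for weaker inhibition. Compound 1 `C=C(Br)C(=O)Nc1cccc(-c2cn3nc(-c4ccc(OCC)cc4)sc3n2)c1` gives 1100 nM in this assay. Compound 2 `C=C(Br)C(=O)Nc1cccc(-c2cn3nc(-c4cccc(OC)c4)sc3n2)c1` gives 1100 nM. Compound 3 `C=C(Br)C(=O)Nc1cccc(-c2cn3nc(-c4ccc(OC)cc4)sc3n2)c1` gives 2300 nM. Compound 3 thus stands highest of the three numbers: a 2.1-fold higher number from compound 1 to compound 3 (0.32 log units; beyond the scatter), and a 2.1-fold higher number from compound 2 to compound 3 (0.32 log units; beyond the scatter), whereas no change at the digits printed from compound 1 to compound 2 (within the scatter).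

Compound 4 `C=C(Br)C(=O)Nc1cccc(-c2cn3nc(-c4ccc(Cl)cc4)sc3n2)c1` has not yet been measured. Compared with compound 3 it carries chloro in place of methoxy on an aromatic carbon. For the measured compounds named here, none of the measured steps bears directly on this change: the step from compound 1 to compound 3 shortens the alkoxy chain, and the step from compound 2 to compound 3 moves the methoxy from 3-methoxyphenyl to 4-methoxyphenyl. Both were modest in size, and both pointed toward weaker inhibition for compound 3. Going by the values given here, a swap of methoxy for chloro has no precedent here, so the direction is open, and the spread of measured numbers is narrow.

Compound 4 is therefore expected near the measured numbers, at 1500 nM in this assay, with a range of 500 nM to 5000 nM. That estimate for compound 4 means an expected step of a 1.5-fold lower number from compound 3 to compound 4 (0.19 log units; within the scatter).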

Compound 4, half-maximal inhibitory concentration: 3000 nM
Beside the measured number, compound 4's estimate is 2.0-fold (0.30 log units) below it; measured number inside the range.
By their numbers in this assay, from the lowest: compounds 1 and 2 (each within the scatter of the next); then compounds 3 and 4 (each within the scatter of the next).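

In this assay, the methoxy-to-chloro swap on the aromatic carbon para to a large group gives a 1.3-fold higher number from compound 3 to compound 4 (0.12 log units; within the scatter), so 4-chlorophenyl and 4-methoxyphenyl cannot be told apart here, even though chloro brings no hydrogen-bond acceptor and methoxy brings one. The comparisons with the other two compounds place compound 4 apart from them, with a 2.7-fold higher number from compound 2 to compound 4 (0.44 log units; beyond the scatter) and a 2.7-fold higher number from compound 1 to compound 4 (0.44 log units; beyond the scatter), both modest, and the second of these shows that ethoxy at this place reads lower than chloro. No measurement available here bears on the reason for these steps.

Still open, on these data alone, is whether a propoxy chain, an amine or a carboxylic acid on the same aromatic carbon would stay in this narrow band or leave it. Also open is whether chloro would respond to a shift around the ring as methoxy does in the step with a 2.1-fold higher number from compound 2 to compound 3 (0.32 log units; beyond the scatter), since the only chloro compound shown carries it as 4-chlorophenyl.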